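Swapping the Aryl Amide for a Dihydroindolyl Amide

This account rests on a few compounds, and the source may have more. Where it says the series, first, only, none or still open, it means among the compounds named here.

Compound 1 `COc1ccc(C)cc1NC(=O)CSc1nnc(-c2ccoc2C)n1Cc1ccco1` gives 2510 nM in a functional assay on CHO cells for antagonist activity at Orexin/Hypocretin receptor type 1 (Homo sapiens), read by FLIPR and calcium flux; a lower number here means a stronger inhibitor, a higher number a weaker inhibitor.
Compound 2 `CC(=O)c1cccc(NC(=O)CSc2nnc(-c3ccoc3C)n2Cc2ccco2)c1` gives 3160 nM in this assay.

For the measured compounds named here, of the two compounds measured so far, compound 2 carries the higher number, but only by the margin seen in a 1.3-fold higher number from compound 1 to compound 2 (0.10 log units; within the scatter), which sits within the scatter; the two compounds therefore cannot be told apart on potency. Compound 3 `Cc1occc1-c1nnc(SCC(=O)NN2CCc3ccccc32)n1Cc1ccco1` changes compound 2 in one place: 2,3-dihydro-1H-indol-1-yl in place of 3-acetylphenyl on an amide-type nitrogen. Going by the values given here, the one measured step exchanged a substituted aromatic ring for another aromatic ring on the same amide-type nitrogen and moved the number hardly at all. Among the compounds with values here, the present change is of a different kind, replacing an aromatic ring by a ring system that is joined through its own nitrogen, so no measured step bears on it directly. With the two measured compounds lying so close together and no guide for this kind of exchange, the expectation for compound 3 is a step of a 1.0-fold higher number from compound 2 to compound 3 (0.01 log units; within the scatter), that is, no shift beyond the scatter, with a wide band of uncertainty. Compound 3 is thus estimated at 3200 nM, within a range from 800 nM to 13000 nM.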

Compound 3, inhibition constant: > 15800 nM
Compound 3 gave a limit, no number; the forecaster's own chance of this, stated with the estimate: 20%; at least 4.9-fold (0.69 log units) between middle value and limit.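

Compound 3 ends at a limit of the assay rather than a number: the limit of > 15800 nM in this assay, at which 1 of the 3 values shown sits. Exchanging 3-acetylphenyl for 2-methoxy-5-methylphenyl had given no clear difference, which could have suggested that this amide-type nitrogen accepts varied groups, yet the 2,3-dihydro-1H-indol-1-yl group gives an at least 5.0-fold higher number from compound 2 to compound 3 (0.69 log units; beyond the scatter) and, set against the other aryl amide, an at least 6.2-fold higher number from compound 1 to compound 3 (0.79 log units; beyond the scatter). So the position does respond to what sits on it, and a six-membered aromatic ring of carbon only, present in all three compounds, is not enough on its own to hold the potency of compound 1 and compound 2.

The entering group differs in two ways at once, with a ring nitrogen as its point of attachment and a five-membered non-aromatic ring, and the compounds shown cannot say which of these goes with the weaker inhibition. A 2,3-dihydro-1H-inden-5-yl group, which keeps both rings but has only carbon in them and joins through an aromatic carbon, or a piperidin-1-yl group, which keeps the ring nitrogen attachment without the aromatic ring, would begin to separate the two.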